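The source may report more compounds than this note shows. Statements on the series, on what has been measured and on what is new or still open speak of the compounds shown alone.

Among the compounds with values here, compound 2 `CN1Cc2c(NC(=O)CN3CCCC3)cccc2C(c2ccccc2)C1` holds the lowest number of the two compounds measured so far: in a functional assay on the whole organism for inhibition of sodium-dependent dopamine transporter (Mus musculus) (a lower number here means that less compound is needed, a higher number that more compound is needed for the effect), compound 2 gives 45 mg/kg, while compound 1 `CCNCCC(=O)Nc1cccc2c1CN(C)CC2c1ccccc1` gives 190 mg/kg. Compound 3 `CN1Cc2c(NC(=O)CN3CCCCC3)cccc2C(c2ccccc2)C1` differs from compound 2 by piperidin-1-yl in place of pyrrolidin-1-yl on a saturated chain carbon bound to a carbonyl carbon. Within the data shown here, the single measured step, closing an open amine chain into a ring, reads a 4.2-fold lower number from compound 1 to compound 2 (0.63 log units; beyond the scatter); no measured step exchanges a five-membered ring for a six-membered one. Such a change is expected to move this assay only within the scatter, so the estimated step is a 1.1-fold lower number from compound 2 to compound 3 (0.05 log units; within the scatter). Compound 3 is therefore estimated at 40 mg/kg, between 18 mg/kg and 90 mg/kg.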

Compound 3, dose for half-maximal effect: about 60 mg/kg
Beside the measured number, compound 3's estimate is 1.5-fold (0.18 log units) below it, within the range that was stated.
By their numbers in this assay, from the lowest: compounds 2 and 3 (each within the scatter of the next); then compound 1.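

In this assay the reading of a 1.3-fold higher number from compound 2 to compound 3 (0.12 log units; within the scatter) means that, on a saturated chain carbon bound to a carbonyl carbon, piperidin-1-yl and pyrrolidin-1-yl cannot be told apart. The six-membered ring also stands clear of the open amine chain, with a 3.2-fold lower number from compound 1 to compound 3 (0.50 log units; beyond the scatter) as its step, so a closed ring of either size gives a lower number than that chain here. Nothing measured explains why these numbers fall as they do. On these data alone, whether morpholin-4-yl, with an oxygen in the ring, or the larger azepan-1-yl would read the same at this place stays open.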